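Ester variation on the shared core: stability read-out

The source may hold more compounds than are shown below. What is called first, only, known or untested is meant among the compounds shown, and "the series" means these compounds.

Measured compounds:
- compound 1 `C[C@@H](O)[C@H]1C(=O)N2C(C(=O)OCOC(=O)C(C)(C)C)=C(S[C@@H]3CN[C@H](C(=O)Nc4cccc(C(=O)O)c4)C3)[C@H](C)[C@H]12` gives > 95% in an ADME assay for metabolic stability, read by LC-MS, with a stated time of 3 h, at pH 6.5, tested at 50 uM; a higher number here means that more of the compound is left, a lower number that less of the compound is left; this is a limit of the assay.
- compound 2 `CCOC(=O)C1=C(S[C@@H]2CN[C@H](C(=O)Nc3cccc(C(=O)OCC)c3)C2)[C@H](C)[C@@H]2[C@@H]([C@@H](C)OC(C)=O)C(=O)N12` gives > 95%; this is a limit.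
- compound 3 `C[C@@H](O)[C@H]1C(=O)N2C(C(=O)OCOC(=O)C(C)(C)C)=C(S[C@@H]3CN[C@H](C(=O)Nc4cccc(C(=O)OCOC(=O)C(C)(C)C)c4)C3)[C@H](C)[C@H]12` gives > 95%; this is a limit.

Compound 1 stands at the limit of this assay; only a limit is known for it, as for the other two values (the limit of > 95% in this assay, at which 3 of the 3 values shown sit). The step that the two limits leave unreadable from compound 1 to compound 3 is therefore unreadable in size. Compound 4 `CC(C)OC(=O)C1=C(S[C@@H]2CN[C@H](C(=O)Nc3cccc(C(=O)O)c3)C2)[C@H](C)[C@@H]2[C@@H]([C@@H](C)O)C(=O)N12` differs from compound 1 by isopropyl in place of (((tert-butyl)carbonyl)oxy)methyl on an oxygen next to a carbonyl group. Among the compounds with values here, no measured step bears on this change with a readable size; the values of compound 2 and compound 3 show only that every measured compound sits at the same limit. Compound 4 is expected to stay at or near that limit, so the step of a number at least 2 percentage points lower from compound 1 to compound 4 (that floor lies within the scatter) is expected to be none beyond the scatter. The estimate for compound 4 in this assay is 93%, between 85% and 98%.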

Compound 4, percent of the compound remaining: > 95%
Compound 4: a limit, no number; the forecaster's own chance of this, stated with the estimate: 65%; at least 2 percentage points between middle value and limit.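

Within the data shown here, compound 1 and compound 4 both stand at a limit in this assay, and no step between them can be read. From the compounds shown here alone, how far the ester variations on the shared core differ in this assay remains open, as does which change, if any, would bring a value off that limit.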